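Cytotoxicity in mouse cells: swapping a side-chain oxolane for benzamide

The source may report more compounds than this note shows. Statements on the series, on what has been measured and on what is new or still open speak of the compounds shown alone.

Measured so far:
compound 1 `OCCn1ncc2c(Nc3ccc(OC(F)(F)F)cc3)ncnc21` — > 10000 nM in an ADME assay on BaF3 cells (Mus musculus) for cytotoxicity; a lower number here means that less compound is needed, a higher number that more compound is needed for the effect
compound 2 `FC(F)(F)Oc1ccc(Nc2ncnc3c2cnn3CC2CCOC2)cc1` — > 10000 nM

Compound 2 stands at the edge of what the assay can report. In this assay compound 2 gives > 10000 nM, which is a limit of the assay and not a number. For the measured compounds named here, the only measured step, a step that the two limits leave unreadable from compound 1 to compound 2, cannot be sized because of the limit of > 10000 nM in this assay, at which 2 of the 2 values shown sit.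

Compound 3 `NC(=O)c1ccc(Cn2ncc3c(Nc4ccc(OC(F)(F)F)cc4)ncnc32)cc1` carries the change (4-carbamoylphenyl in place of oxolan-3-yl on a saturated chain carbon bound to an aromatic nitrogen). Going by the values given here, no measured step gives a readable size for comparison, so the expectation rests on the fact that both measured compounds sit at the limit. Compound 3 is therefore expected to stay near that limit, with a step that the limit leaves unreadable from compound 2 to compound 3 as the estimated step. The estimate for compound 3 in this assay is 12000 nM, with a range from 3000 nM to 40000 nM.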

Compound 3, half-maximal effective concentration: > 10000 nM
Compound 3 ended at the assay's limit; the forecaster's own chance of this, stated with the estimate: 70%; the middle value does not contradict the limit.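

No new step can be read between compound 1, compound 2 and compound 3 in this assay, because all three values are limits of the assay and not numbers: the limit of > 10000 nM in this assay, at which 3 of the 3 values shown sit. The compounds shown leave open whether these side chains differ at all in this read-out.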